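A few compounds are considered here, and "the series" means these few. Any claim that something is new, unique, unknown or untested is made for them only; others in the source may bear on it.

Measured in a functional assay on DU-145 cells (Homo sapiens) for cytotoxicity, read by MTT assay, with a stated time of 48 h; a higher number here means a weaker inhibitor, a lower number a stronger inhibitor:

Compound 1 `CCOC(=O)c1c(-c2c(Cl)c3ccccc3oc2=O)nn(-c2ccccc2)c1C(=O)OCC`: 48000 nM
Compound 2 `CCOC(=O)c1c(-c2c(Cl)c3ccccc3oc2=O)nn(-c2ccc(OC)cc2)c1C(=O)OCC`: 25000 nM
Compound 3 `CCOC(=O)c1c(-c2c(Cl)c3ccccc3oc2=O)nn(-c2cccc(Cl)c2)c1C(=O)OCC`: 24000 nM

Among these three, compound 1 gives the highest number, yet the other two lie within the usual scatter of it: a 1.9-fold lower number from compound 1 to compound 2 (0.28 log units; within the scatter) and a 2.0-fold lower number from compound 1 to compound 3 (0.30 log units; within the scatter). Compound 4 `CCOC(=O)c1c(-c2cc3ccccc3oc2=O)nn(-c2ccccc2)c1C(=O)OCC` differs from compound 1 at another place: hydrogen in place of chloro on an aromatic carbon. Among the measured compounds shown here, no measured step touches this carbon; all three measured steps change only the group on the ring nitrogen, and none moved the number beyond the scatter, including a 1.0-fold lower number from compound 2 to compound 3 (0.02 log units; within the scatter). Nothing measured therefore bears directly on this change, and a step in this assay no larger than the scatter is expected, in either direction. Compound 4 is accordingly estimated at 48000 nM, with a range from 20000 nM to 120000 nM. This expectation amounts to no change at the digits printed from compound 1 to compound 4 (within the scatter).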

Compound 4, half-maximal inhibitory concentration: 57000 nM
Beside the measured number, compound 4's estimate is 1.2-fold (0.07 log units) below it, within the range that was stated.
By their numbers in this assay, from the lowest: compounds 3, 2, 1 and 4 (each within the scatter of the next, the first and the last beyond it).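

With hydrogen in place of chloro on this aromatic carbon, opposite the ring oxygen, this assay shows a 1.2-fold higher number from compound 1 to compound 4 (0.07 log units; within the scatter). This first look at the position shows that, with phenyl on the ring nitrogen, the chlorine can go without a change beyond the scatter. No supporting data explain this result. As far as these compounds go, whether an amine or a carboxylic acid on this carbon would move the number remains open. So does whether the same swap would behave alike with 4-methoxyphenyl or 3-chlorophenyl on the ring nitrogen.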